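The source may report more compounds than this note shows. Statements on the series, on what has been measured and on what is new or still open speak of the compounds shown alone.

In a functional assay on PC-3 cells (Homo sapiens) for cytotoxicity, read by WST assay, with a stated time of 72 h (a higher number here means a weaker inhibitor, a lower number a stronger inhibitor), three compounds with a shared core have been tested. Among the measured compounds shown here, compound 2 (`O=C1Nc2c(ccc(F)c2F)C1(c1ccc(O)cc1)c1cccs1`) gives 0.3 nM as the only single number among them. Compound 1 (`CCCOc1ccc(C2(c3ccc(O)cc3)C(=O)Nc3c2ccc(F)c3F)cc1`) gives > 1000 nM and this is a limit, not a number. The step followed here leads from compound 2 to compound 4 (`O=C1Nc2c(ccc(F)c2F)C1(c1ccc(O)cc1)C1CCCCCC1`), with cycloheptyl in place of thiophen-2-yl on a saturated ring carbon. The closest guide is compound 3 (`O=C1Nc2c(ccc(F)c2F)C1(c1ccc(O)cc1)C1CCCCC1`), which also carries a non-aromatic ring of carbon only at that place. Compound 3 gave 9.2 nM; 32 nM; > 1000 nM (3 entries) over repeated measurements. The entries of compound 3 include (the limit of > 1000 nM in this assay, at which 1 of the 3 values shown sits). For the measured compounds named here, these entries disagree widely (the several entries of compound 3 in this assay, 9.2 nM; 32 nM; > 1000 nM (3 entries)), so the guide is a loose one, yet each of them sits higher than the single number of compound 2. On that evidence a large step toward weaker inhibition is expected (a 100-fold higher number from compound 2 to compound 4 (2.00 log units; beyond the scatter)). For compound 4 the estimate is 30 nM with an expected range from 3 nM to 600 nM in this test.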

Compound 4, half-maximal inhibitory concentration: 12 nM
Compound 4: the middle estimate sits 2.5-fold (0.40 log units) above what was measured, within the range that was stated.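

In this assay, placing cycloheptyl instead of thiophen-2-yl on the saturated ring carbon gives a 40-fold higher number from compound 2 to compound 4 (1.60 log units; beyond the scatter). So at this place, the aromatic five-membered ring of compound 2 gives a much lower number than this seven-membered carbon ring, yet compound 4 still gives a single number rather than a limit. Until now, the only guide to a non-aromatic ring of carbon only at this place was compound 3, whose entries disagree widely: the several entries of compound 3 in this assay, 9.2 nM; 32 nM; > 1000 nM (3 entries)

The compounds shown do not separate the loss of the aromatic ring from the change in ring size as the source of this step. A cyclopentyl group at this place, matching the five-membered size of thiophen-2-yl without its aromatic ring, would help to tell these two apart.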